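This account rests on a few compounds, and the source may have more. Where it says the series, first, only, none or still open, it means among the compounds named here.

Measured compounds:
compound 1 `Fc1ccc2nc(-c3cncs3)n(C3CC3)c2c1`, 62 nM
compound 2 `Fc1cc2nc(-c3cncnc3)n(C3CC3)c2cc1F`, 22 nM
compound 3 `N#Cc1ncncc1-c1nc2cc(F)c(F)cc2n1C1CC1`, 13 nM

In an assay on cells for inhibition of cytochrome P450 11B2, mitochondrial (Homo sapiens), read by HPLC, with a stated time of 90 min (on this read-out lower numbers stand for stronger inhibition and higher numbers for weaker inhibition), compound 2 stands second highest of the three numbers. Its nearest neighbour is compound 3, reached by a 1.7-fold lower number from compound 2 to compound 3 (0.23 log units; within the scatter); its furthest is compound 1, which gives 62 nM. Compound 2 itself gives 22 nM, and the gap between these two values lies beyond the scatter.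

Compound 4 `CC(F)(F)c1ncncc1-c1nc2cc(F)c(F)cc2n1C1CC1` differs from compound 2 by 1,1-difluoroethyl in place of hydrogen on an aromatic carbon. Among the compounds with values here, the only measured step that bears on it is a 1.7-fold lower number from compound 2 to compound 3 (0.23 log units; within the scatter), in which a different group entered the same aromatic carbon and the number stayed within the scatter. A step of similar small size is therefore expected, if anything toward a lower number.

Compound 4 is estimated at 15 nM (range 6 nM to 40 nM), which would mean an expected 1.5-fold lower number from compound 2 to compound 4 (0.17 log units; within the scatter).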

Compound 4, half-maximal inhibitory concentration: 50 nM
Compound 4: middle estimate off by 3.3-fold (0.52 log units), on the low side, and the stated range ends below it.
By their numbers in this assay, from the lowest: compounds 3 and 2 (each within the scatter of the next); then compounds 4 and 1 (each within the scatter of the next).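

In this assay, this aromatic carbon does not respond to every group alike: 1,1-difluoroethyl gives a 2.3-fold higher number from compound 2 to compound 4 (0.36 log units; beyond the scatter) and so moves the number beyond the scatter, which the cyano step did not do. Replacing cyano with 1,1-difluoroethyl gives a 3.8-fold higher number from compound 3 to compound 4 (0.59 log units; beyond the scatter) on the same core, so the outcome here depends on which group enters. Nothing measured here accounts for this difference. The compounds shown leave open whether an ethyl group without the fluorines would give a similar step. They also leave open how an amine or a longer chain would read at this carbon.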